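From Halophenyl to Methoxyphenyl on a Shared Core

The compounds below may be only part of what the source reports. "The series", "measured", "known", "first", "only" and "open" are said of these compounds alone.

Compound 1 `OC(CCn1nc2c(Br)c(Br)c(Br)c(Br)c2n1)c1ccc(Br)cc1` was tested in a functional assay on MCF7 cells (Homo sapiens) for antiproliferative activity, read by MTT assay, with a stated time of 48 h, tested at 100 uM (a lower number here means a stronger effect, a higher number a weaker effect of the compound at the concentration tested), where compound 1 gives 0%. Compound 3 `OC(CCn1nc2c(Br)c(Br)c(Br)c(Br)c2n1)c1ccc(Cl)cc1` gives 0%, and compound 2 `OC(CCn1nc2c(Br)c(Br)c(Br)c(Br)c2n1)c1cccc(Cl)c1` gives 0.5%. Compound 1 stands level with compound 3 at the digits shown, the two together being the lowest of the three numbers; its nearest neighbour is compound 3 and its furthest compound 2. All measured steps are small: no change at the digits printed from compound 1 to compound 3 (within the scatter), a number 0.5 percentage points higher from compound 1 to compound 2 (within the scatter) and a number 0.5 percentage points lower from compound 2 to compound 3 (within the scatter), each within the scatter.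

Compound 4 `COc1cccc(C(O)CCn2nc3c(Br)c(Br)c(Br)c(Br)c3n2)c1` differs from compound 1 as follows: 3-methoxyphenyl in place of 4-bromophenyl on a saturated chain carbon bound to an oxygen on a saturated carbon and a saturated chain carbon. Going by the values given here, the steps that bear on this change are those exchanging 4-bromophenyl for 3-chlorophenyl and bromo for chloro on the same saturated chain carbon, and both stayed within the scatter. Among the compounds with values here, no measured pair brings a methoxy group in place of a halogen, so the change in compound 4 reaches beyond what the measured steps cover. The expectation nonetheless rests on compound 1 at 0% and on the flat steps a number 0.5 percentage points higher from compound 1 to compound 2 (within the scatter) and no change at the digits printed from compound 1 to compound 3 (within the scatter). Compound 4 is therefore expected to show a step of a number 1 percentage points higher from compound 1 to compound 4 (within the scatter), none beyond the scatter. The estimate for compound 4 is 1%, within a range from 0% to 15%.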

Compound 4, a percentage reported as activity, at one concentration (the size of the read-out at that concentration, not a potency): 6%
Compound 4: middle estimate off by 5 percentage points, on the low side; low and high end bracket the measured number.
By their numbers in this assay, from the lowest: compounds 1, 3, 2 and 4 (each within the scatter of the next).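

The measured steps now reach beyond an exchange of one halogen for another. On the saturated chain carbon bound to an oxygen on a saturated carbon and a saturated chain carbon, 3-methoxyphenyl brings one hydrogen-bond acceptor where the halophenyl groups count none, yet this assay shows a number 6 percentage points higher from compound 1 to compound 4 (within the scatter) and a number 6 percentage points higher from compound 3 to compound 4 (within the scatter). The cleanest comparison, methoxy in place of chloro on an aromatic carbon, gives a number 5.5 percentage points higher from compound 2 to compound 4 (within the scatter), so at this place all four compounds read within the scatter of one another, and the series offers no ranking among them. No measurement available here accounts for this flat reading.

The compounds shown leave open whether any group on this aromatic ring can carry the number beyond the scatter, for example an amine or a carboxylic acid in place of the methoxy group. They also leave open whether a longer chain between the shared core and the carbon bearing the oxygen would give a step of that size in this assay.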